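Working notes: methoxy in place of hydrogen on compound 2

The compounds below may be only part of what the source reports. "The series", "measured", "known", "first", "only" and "open" are said of these compounds alone.

Among the measured compounds shown here, in a physicochemical assay for acid dissociation, compound 1 `CC(=O)OCCS(=O)(=O)c1ccc(S(N)(=O)=O)s1` gives 8.65 and compound 2 `CC(=O)OCCCS(=O)(=O)c1ccc(S(N)(=O)=O)s1` gives 8.05 as the only two numbers so far, which leaves compound 2 the lower of the pair. Compound 3 `COCC(=O)OCCCS(=O)(=O)c1ccc(S(N)(=O)=O)s1` has not yet been measured. It differs from compound 2 by methoxy in place of hydrogen on a saturated chain carbon bound to a carbonyl carbon in that methoxy stands in place of hydrogen on a saturated chain carbon bound to a carbonyl carbon, so acetoxy turns into ((methoxymethyl)carbonyl)oxy. For the measured compounds named here, one measured step bears on this, and only loosely. The step of a number 0.60 log units lower from compound 1 to compound 2 (beyond the scatter) is modest and comes from a different change, acetoxymethyl in place of acetoxy, so it serves as a rough gauge of size and not as a direct precedent. Going by the values given here, no measured step covers a methoxy change, so no shift beyond the scatter is expected in this assay for this change and a higher number is no more expected than a lower one. The expected a number 0.05 log units higher from compound 2 to compound 3 (within the scatter) is an estimate that stays within the scatter. For compound 3 the estimated value is 8.1 with an expected range from 7.75 to 8.5 for this measurement.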

Compound 3, acid dissociation constant: 8.1
The estimate for compound 3 equals the measured number at the digits printed; the range from low to high includes it.
By their numbers in this assay, from the lowest: compounds 2 and 3 (each within the scatter of the next); then compound 1.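

Working notes: in this assay, methoxy in place of hydrogen on a saturated chain carbon bound to a carbonyl carbon gives a number 0.05 log units higher from compound 2 to compound 3 (within the scatter) and so, on the chain of compound 2, this read-out does not separate acetoxy from ((methoxymethyl)carbonyl)oxy. The distance from compound 1 stays in place with the new group, as a number 0.55 log units lower from compound 1 to compound 3 (beyond the scatter) reads much like a number 0.60 log units lower from compound 1 to compound 2 (beyond the scatter) and so the separation from compound 1 appears with both end groups among these three compounds. No supporting measurement is available to explain either step.

This single replacement leaves open whether a dimethylamino group or a carboxylic acid on the same saturated chain carbon would also stay within the scatter of compound 2 or would move the number beyond it. Going by these compounds, it is also open whether methoxy would give the same small step on the chain of compound 1, or on a longer chain between the sulfonyl sulfur and the ester oxygen.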